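A few compounds are considered here, and "the series" means these few. Any claim that something is new, unique, unknown or untested is made for them only; others in the source may bear on it.

Compound 3 `CC(C)(C)CNc1nc(NCC2CC2)cc(-c2ccccn2)n1` gives 5000 nM in a functional assay on HEK293 cells for agonist activity at G-protein coupled receptor 39 (Homo sapiens), read by inositol phosphate accumulation (on this read-out higher numbers stand for an effect only at larger amounts of compound and lower numbers for an effect already at smaller amounts), the highest of the three numbers measured here. Its nearest neighbour is compound 1 `COCCNc1nc(NCC2CC2)cc(-c2ccccn2)n1`, which gives 2200 nM in this assay; compound 2 `CNc1nc(NCc2ccc(Cl)cc2)cc(-c2ccccn2)n1` gives 15 nM and lies far away from compound 3.

Compound 4 `CN(C)c1nc(NCC2CC2)cc(-c2ccccn2)n1` differs from compound 3 in one place: dimethylamino in place of neopentylamino on an aromatic carbon. For the measured compounds named here, only one measured step bears on this change: a 2.3-fold higher number from compound 1 to compound 3 (0.36 log units; beyond the scatter), where a bulkier chain on the amine raised the number. Compound 4 goes the other way, to a much smaller group on that ring carbon, so a lower number than compound 3 is expected, though the exchange also removes the hydrogen-bond donor, and nothing measured here tells how much that matters. Compound 2 reaches a low number with a small methylamino group, but it also carries a different second group, so it does not isolate this change.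

Compound 4 is therefore expected to give about 1000 nM in this assay, within a range from 200 nM to 5000 nM, a step of a 5.0-fold lower number from compound 3 to compound 4 (0.70 log units; beyond the scatter).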

Compound 4, half-maximal effective concentration: > 25000 nM
Compound 4 ended at the assay's limit (the forecaster's own chance of this, stated with the estimate: 10%); middle value at least 25-fold (1.39 log units) away from the limit.
By their numbers in this assay, from the lowest: compound 2; then compound 1; then compound 3. At a limit, above all of these: compound 4.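

In this assay compound 4 stands at a limit of the read-out, not at a number: the limit of > 25000 nM in this assay, at which 1 of the 4 values shown sits.

The smaller dimethylamino group did not bring a lower number on this aromatic carbon: the exchange gave an at least 5.0-fold higher number from compound 3 to compound 4 (0.69 log units; beyond the scatter), and the exchange for (2-methoxyethyl)amino gave an at least 11-fold higher number from compound 1 to compound 4 (1.05 log units; beyond the scatter). Among these three compounds, then, a smaller group on this carbon does not go with a lower number, and the rise comes with an exchange that also leaves dimethylamino with no hydrogen-bond donor, unlike neopentylamino.

The compounds shown cannot separate the loss of that donor from the other differences between these groups. An ethylamino group, which is short but keeps the donor, and a diethylamino group, which has none, on the same core would bear on this question.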